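A few compounds are considered here, and "the series" means these few. Any claim that something is new, unique, unknown or untested is made for them only; others in the source may bear on it.

Compound 1, `CN(C)CCCOc1ccc(CN2CC[C@H](NC(=O)c3cccs3)C2)cc1`, measured in an assay on HEK293 cells for binding affinity to Urotensin-2 receptor (Homo sapiens), read by radioligand binding; a higher number here means a weaker inhibitor, a lower number a stronger inhibitor: compound 1 gives < 10000 nM, which is a limit of the assay and not a number.
Compound 2, `CC(C)C[C@@H](NC(=O)c1cc2ccccc2o1)C(=O)N[C@H]1CCN(Cc2ccc(OCCCN(C)C)cc2)C1`: in this assay compound 2 gives 3160 nM.
Compound 3, `CC(C)C[C@H](NC(=O)c1ccc2ccccc2n1)C(=O)N[C@H]1CCN(Cc2ccc(OCCCN(C)C)cc2)C1`: in this assay compound 3 gives 631 nM.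

Compound 3 stands lowest of the two numbers shown in this assay. Its nearest neighbour is compound 2, whose value sits above it by a gap beyond the usual scatter. Compound 1 sits at the limit of < 10000 nM in this assay, at which 1 of the 3 values shown sits, so no number for it can be set beside the other two.

Compound 4, `CC(C)C[C@H](NC(=O)c1ccncc1)C(=O)N[C@H]1CCN(Cc2ccc(OCCCN(C)C)cc2)C1`, has not yet been measured. It differs from compound 3 in one place: pyridin-4-yl in place of quinolin-2-yl on a carbonyl carbon. For the measured compounds named here, no pair among the measured compounds shows this change alone. What the measured compounds show is that the aromatic group on that carbonyl carbon matters: compound 2, with a different group there, gives 3160 nM, beyond the scatter from compound 3. The smaller group in compound 4 is expected to weaken binding, with a step of a 4.0-fold higher number from compound 3 to compound 4 (0.60 log units; beyond the scatter). Compound 4 is therefore estimated at 2500 nM, within a range from 800 nM to 8000 nM.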

Compound 4, inhibition constant: 2000 nM
Compound 4: middle estimate off by 1.3-fold (0.10 log units), on the high side, and the stated range covers the measured number.
By their numbers in this assay, from the lowest: compound 3; then compounds 4 and 2 (each within the scatter of the next).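

In this assay, pyridin-4-yl in place of quinolin-2-yl on a carbonyl carbon gives a 3.2-fold higher number from compound 3 to compound 4 (0.50 log units; beyond the scatter). For the compounds shown here, this is the first comparison in which the group on that carbonyl carbon changes while the rest of the molecule stays fixed, and it shows that this change alone moves the number beyond the scatter. The two groups have the same counts of hydrogen-bond donors and acceptors and differ by the carbon-only aromatic ring of quinolin-2-yl, but nothing measured here gives a cause for the step.

The compounds shown leave open whether that carbon-only ring or the place of the ring nitrogen matters more, which a phenyl or a naphthyl group on the same carbonyl could help separate. They also leave open how a carboxylic acid or a longer chain at this position would read.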